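Compound 1 and a sulfur-linked relative

The compounds below may be only part of what the source reports. "The series", "measured", "known", "first", "only" and "open" are said of these compounds alone.

In a functional assay on OVCAR-3 cells (Homo sapiens) for inhibition, read by sulforhodamine B assay, with a stated time of 48 h (a lower number here means a stronger inhibitor of growth, a higher number a weaker inhibitor of growth), compound 1 `Nc1cc(N)c2nc(-c3ccccc3)c(Oc3ccc(Cl)c(Cl)c3)nc2c1` gives 10700 nM.
In this assay compound 2 `COc1ccc(CNc2nc3cc(N)cc(N)c3nc2-c2ccccc2)cc1OC` gives 1320 nM.

Of these two numbers, compound 1 has the highest; compound 2 lies lower by a gap beyond the scatter, so compound 2 is the stronger of the pair. Compound 3 `Nc1cc(N)c2nc(-c3ccccc3)c(Sc3ccc(Cl)c(Cl)c3)nc2c1` differs from compound 1 in one place: (3,4-dichlorophenyl)sulfanyl in place of 3,4-dichlorophenoxy on an aromatic carbon. Going by the values given here, no measured pair shows this swap of oxygen for sulfur, so there is no step on which to lean. The expectation is a change no larger than the scatter, with no clear direction, written as a 1.2-fold lower number from compound 1 to compound 3 (0.08 log units; within the scatter). Compound 3 is therefore estimated at 9000 nM, within a range from 3000 nM to 27000 nM.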

Compound 3, concentration for 50% growth inhibition: 11700 nM
Compound 3: middle estimate off by 1.3-fold (0.11 log units), on the low side; the range from low to high includes it.
By their numbers in this assay, from the lowest: compound 2; then compounds 1 and 3 (each within the scatter of the next).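

In this assay, replacing the oxygen link to the dichlorophenyl ring with a sulfur link gives a 1.1-fold higher number from compound 1 to compound 3 (0.04 log units; within the scatter), so at this position the two linking atoms cannot be told apart in growth inhibition. Going by these compounds alone, this is the first direct comparison of the two links on an otherwise unchanged compound. Nothing in the available data explains this match.

The compounds shown leave open whether a longer carbon chain as the link would move the number. They also leave open what a carboxylic acid on the dichlorophenyl ring would do.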